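From Methyl to 2-Phenylethenyl on a Shared Core

The compounds below may be only part of what the source reports. "The series", "measured", "known", "first", "only" and "open" are said of these compounds alone.

Compound 1 `COc1ccc(Nc2cc(C)oc(=O)c2)cc1` was tested in a functional assay on KBVIN cells (Homo sapiens) for cytotoxicity, read by MTT assay, with a stated time of 72 h; a lower number here means that less compound is needed, a higher number that more compound is needed for the effect. In this assay compound 1 gives > 30 uM, which is a limit of the assay rather than a measured number. Its standing is marked by the limit of > 30 uM in this assay, at which 1 of the 2 values shown sits. A second compound, compound 2 `O=c1cc(Nc2ccccc2)cc(-c2ccccc2)o1`, was measured in this assay, where compound 2 gives 0.15 uM. Within the data shown here, no single step between compound 1 and compound 2 is described; their two values show only that one sits at the limit and the other lies far below it.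

Compound 3 `COc1ccc(Nc2cc(/C=C/c3ccccc3)oc(=O)c2)cc1` has not yet been measured. It differs from compound 1 by 2-phenylethenyl in place of methyl on an aromatic carbon, in words 2-phenylethenyl in place of methyl on an aromatic carbon. For the step from compound 1 to compound 3 in this assay a move toward greater potency, well beyond the usual scatter, is expected, since compound 2 with its phenyl group gives 0.15 uM. Compound 3 is therefore estimated at 1 uM in this assay, with a range from 0.1 uM to 20 uM. This expected step is an at least 30-fold lower number from compound 1 to compound 3 (1.47 log units; beyond the scatter).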

Compound 3, concentration for half-maximal effect: 0.1 uM
For compound 3 the middle estimate is 10-fold (1.00 log units) above the measured one; the range from low to high includes it.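

In this assay, among these compounds, the change from methyl to 2-phenylethenyl on an aromatic carbon next to the ring oxygen gives an at least 300-fold lower number from compound 1 to compound 3 (2.47 log units; beyond the scatter), and this is the first step here in which only this one place differs, so the large shift can be tied to this position and this exchange rather than to a comparison across several differences. On these data alone, compound 1 gives > 30 uM in this assay, which is a limit of the assay and not a number, so the step has a floor but no upper bound, and its true size stays unknown: the limit of > 30 uM in this assay, at which 1 of the 3 values shown sits. The step also shows that this position accepts the larger group, with its six-membered aromatic ring and its double bond outside that ring, without any loss in this read-out.

The compounds shown leave open whether the step depends on the aromatic ring, on the double bond, or on both, a question that 2-phenylethyl or plain ethyl at this position could separate. They also leave open how an amine or a carboxylic acid on the end of the 2-phenylethenyl group would fare.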